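The source may hold more compounds than are shown below. What is called first, only, known or untested is meant among the compounds shown, and "the series" means these compounds.

Compound 1 `CCCOc1ccc(C(=O)NNc2c(Br)cccc2Br)cc1` was examined in a toxicity assay on MDCK cells (Canis lupus familiaris) for cytotoxicity, read by CCK-8 assay, with a stated time of 48 h; a lower number here means that less compound is tolerated, a higher number that more compound is tolerated. In this assay compound 1 gives > 100000 nM, which is a limit of the measurement and not a number. Compound 2 `CCOc1ccc(C(=O)Nc2c(Br)cccc2Br)cc1` likewise reaches only a limit in this assay, giving > 100000 nM. Compound 3 `CCOc1ccc(C(=O)NNc2c(Br)cc(Br)cc2Br)cc1` does give a number in this assay, namely 54800 nM. Compound 1 thus stands at the limit of > 100000 nM in this assay, at which 2 of the 3 values shown sit. Compound 4 `CCN(CC)c1ccc(C(=O)NNc2c(Br)cccc2Br)cc1` carries the same core with a single change: diethylamino in place of propoxy on an aromatic carbon. With two of the three values at the limit, little room for movement appears in this assay, and the step from compound 1 to compound 4 is expected to stay within the scatter, most probably at the limit again. Compound 4 is therefore estimated at 100000 nM, between 40000 nM and 300000 nM. The expected step is a number no higher from compound 1 to compound 4 (the limit leaves the size open).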

Compound 4, half-maximal cytotoxic concentration: 34000 nM
Beside the measured number, compound 4's estimate is 2.9-fold (0.47 log units) above it, outside the stated range (below it).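

Diethylamino in place of propoxy on an aromatic carbon, para to a large group, gives an at least 2.9-fold lower number from compound 1 to compound 4 (0.46 log units; beyond the scatter) in this assay. For the compounds shown here, the earlier compounds offered no step at all, so this is the first sign that the group at this position bears on how much compound the cells tolerate. From the compounds shown here alone, compound 1 gives > 100000 nM, which is a limit and not a number, so the full size of the step stays open: the limit of > 100000 nM in this assay, at which 2 of the 4 values shown sit.

Going by these compounds, whether a smaller amine such as dimethylamino, or a longer alkoxy chain such as butoxy, would shift the number at this position remains open.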